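The compounds below may be only part of what the source reports. "The series", "measured", "known", "first", "only" and "open" are said of these compounds alone.

Compound 1, `N/C(CC(O)c1cccc2ccccc12)=N\N=C\c1cccc(Br)c1`: 3900 nM
Compound 2, `N/C(CC(O)c1ccc2ccccc2c1)=N\N=C\c1ccc(F)cc1`: > 298000 nM

Within the data shown here, in an ADME assay on L6 cells (Rattus norvegicus) for cytotoxicity, read by resazurin assay, with a stated time of 72 h (on this read-out lower numbers stand for stronger inhibition and higher numbers for weaker inhibition), compound 1 holds the only numerical value shown. Compound 2 reaches only a limit of the assay, (the limit of > 298000 nM in this assay, at which 1 of the 2 values shown sits). Compound 3, `N/C(CC(O)c1cccc2ccccc12)=N\N=C\c1ccco1`, differs from compound 1 by furan-2-yl in place of 3-bromophenyl on a carbon with a double bond to nitrogen. Among the measured compounds shown here, no measured pair carries this change, so the size of the step is uncertain; the writer expects a weakening of cytotoxicity in the step of a 3.8-fold higher number from compound 1 to compound 3 (0.59 log units; beyond the scatter), somewhat beyond the scatter. Compound 3 is estimated at 15000 nM in this assay, with a range from 3000 nM to 100000 nM.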

Compound 3, half-maximal inhibitory concentration: 145000 nM
The estimate for compound 3 lay 9.7-fold (0.99 log units) below the measured number; the measured number lies above the stated range.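

In this assay, this first measured pair shows that the group on the carbon with a double bond to nitrogen matters for cytotoxicity: furan-2-yl in place of 3-bromophenyl gives a 37-fold higher number from compound 1 to compound 3 (1.57 log units; beyond the scatter). The core of compound 1 therefore does not set the value alone, since this one change moves it well beyond the scatter. Nothing measured here accounts for the size of the step.

The compounds shown leave open whether the weakening follows the loss of the bromine or the change of ring. A plain phenyl group at this place would separate the two.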